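The source may hold more compounds than are shown below. What is called first, only, known or untested is meant among the compounds shown, and "the series" means these compounds.

Measured in a functional assay on SF-295 cells (Homo sapiens) for cytotoxicity, read by sulforhodamine B assay, with a stated time of 48 h; a lower number here means a stronger inhibitor of growth, a higher number a weaker inhibitor of growth:
- compound 1 `Nc1nc(Cl)c2ncn(Cc3ccccc3CCl)c2n1`: 7410 nM
- compound 2 `ClCc1ccc(Cn2cnc3c(Cl)nc(Cl)nc32)cc1`: 7240 nM
- compound 3 `ClCc1ccccc1Cn1cnc2c(Cl)nc(Cl)nc21`: 1900 nM

Compound 3 gives the lowest number of the three; compound 1 and compound 2 both sit higher, each beyond the scatter. Compound 4 `ClCc1ccccc1Cn1cnc2c(Cl)ncnc21` differs from compound 3 in one place: hydrogen in place of chloro on an aromatic carbon. For the measured compounds named here, the only measured step, a 3.9-fold lower number from compound 1 to compound 3 (0.59 log units; beyond the scatter), concerns the same aromatic carbon but exchanges amino for chloro, not chloro for hydrogen; it shows that the group at this carbon moves the number, without saying what a bare hydrogen does there. Removal of the chloro is expected to cost something, a modest rise in the number, a 2.1-fold higher number from compound 3 to compound 4 (0.32 log units; beyond the scatter). Compound 4 is therefore estimated at 4000 nM, within 1500 nM to 12000 nM.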

Compound 4, concentration for 50% growth inhibition: 10500 nM
Compound 4: middle estimate off by 2.6-fold (0.42 log units), on the low side; the range from low to high includes it.
By their numbers in this assay, from the lowest: compound 3; then compounds 2, 1 and 4 (each within the scatter of the next).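

In this assay, the chloro between two ring nitrogen atoms matters in its own right, since replacing it with hydrogen gives (a 5.5-fold higher number from compound 3 to compound 4 (0.74 log units; beyond the scatter)). Amino and hydrogen at this carbon are not separated (a 1.4-fold higher number from compound 1 to compound 4 (0.15 log units; within the scatter)), so of these three groups only chloro stands apart. No evidence is available that bears on the reason for this result.

From the compounds shown here alone, whether fluoro, methoxy or a dimethylamino group at this carbon would match chloro remains open. Also open, going by these compounds, is whether the same chloro step would hold on the core of compound 2.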